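The compounds below may be only part of what the source reports. "The series", "measured", "known", "first", "only" and "open" are said of these compounds alone.

Series notes, tertiary aniline amides with a sulfamate.

Compound 1 `CCN(Cc1ccc(Br)cc1)c1cccc(C(=O)N2CCc3ccc(OS(N)(=O)=O)cc3C2)c1` gives 84.5% in an assay on HEK293 cells for inhibition of Steryl-sulfatase (Homo sapiens), tested at 1 uM; on this read-out lower numbers stand for a weaker effect and higher numbers for a stronger effect at the one concentration tested. Among the measured compounds shown here, compound 2 `CCN(Cc1ccncc1)c1cccc(C(=O)N2CCc3ccc(OS(N)(=O)=O)cc3C2)c1` gives 52.8% in this assay, the lower of the two numbers so far; the single step recorded, a number 31.7 percentage points lower from compound 1 to compound 2 (beyond the scatter), separates it from compound 1.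

Compound 3 `NS(=O)(=O)Oc1ccc2c(c1)CN(C(=O)c1cccc(N3CCCCC3)c1)CC2` is the next member, with the change (piperidin-1-yl in place of ethyl((pyridin-4-yl)methyl)amino on an aromatic carbon).

For the measured compounds named here, only the step from compound 1 to compound 2 bears on this, and it shows that what sits on the aromatic nitrogen moves the read-out by a large amount. Going by the values given here, no pair of measured compounds shows the exchange of an ethyl((pyridin-4-yl)methyl)amino group for piperidin-1-yl, so the direction is open. The expected step is a number 7.2 percentage points higher from compound 2 to compound 3 (within the scatter). Compound 3 is therefore estimated at 60%, with a range from 35% to 82% reflecting the uncertainty.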

Compound 3, a percentage reported as inhibition, at one concentration (the size of the read-out at that concentration, not a potency): 11.9%
Estimate against measurement, compound 3: 48.1 percentage points above, outside the stated range (below it).
By their numbers in this assay, from the lowest: compound 3; then compound 2; then compound 1.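

The earlier step changed only the ring on the ethyl-substituted amino group, whereas compound 3 replaces the whole group with piperidin-1-yl and carries no aromatic ring at this aromatic carbon. In this assay this change gives a number 40.9 percentage points lower from compound 2 to compound 3 (beyond the scatter), and the comparison with the 4-bromobenzyl member gives a number 72.6 percentage points lower from compound 1 to compound 3 (beyond the scatter), so compound 3 stands lowest of the three, with both of its steps beyond the scatter. Nothing measured here accounts for this fall.

Loss of the aromatic ring, the smaller group and the closing of the open amine into a ring all come together in this change, so their separate contributions remain open. An ethyl(benzyl)amino group or a 4-benzylpiperidin-1-yl group on the same aromatic carbon would help to separate them.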